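The source may hold more compounds than are shown below. What is called first, only, known or untested is meant among the compounds shown, and "the series" means these compounds.

Three compounds share one core and were tested in an assay on HEK-293T cells for displacement of a labelled ligand from corticotropin-releasing factor receptor 2 (Homo sapiens), read by scintillation counting, with a stated time of 2 h, tested at 1 uM; on this read-out higher numbers stand for more inhibition at the one concentration tested (going by the name of the read-out) and lower numbers for less inhibition. Compound 1 `CCCCN(CC)c1cc(C)nc2c1NC(=O)CN2c1ccc(C)cc1C` gives 6.8% in this assay. Compound 2 `CCCCN(CC)c1cc(C)nc2c1NC(=O)CN2c1ccc(Br)cc1Br` gives 9.4% in this assay, and compound 3 `CCCCN(CC)c1cc(C)nc2c1NC(=O)CN2c1ccc(C)cc1Br` gives 5.5% in this assay. The numbers of compound 3, compound 1 and compound 2 all lie within the usual scatter of one another, so none can be told apart. Compound 4 `CCCCN(CC)c1cc(C)nc2c1NC(=O)CN2c1ccc(OC)cc1C` differs from compound 3 by 4-methoxy-2-methylphenyl in place of 2-bromo-4-methylphenyl on a nitrogen on an aromatic ring in a ring. The measured steps that bear on this change, each a swap of the same group, are a number 2.6 percentage points higher from compound 1 to compound 2 (within the scatter), a number 1.3 percentage points lower from compound 1 to compound 3 (within the scatter) and a number 3.9 percentage points lower from compound 2 to compound 3 (within the scatter). None went beyond the scatter, so no step beyond the scatter is expected here either. The expected step is a number 1.5 percentage points higher from compound 3 to compound 4 (within the scatter). Compound 4 is therefore estimated at 7% in this assay, with a range from -3% to 17%.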

Compound 4, a percentage reported as inhibition, at one concentration (the size of the read-out at that concentration, not a potency): -2.3%
Estimate against measurement, compound 4: 9.3 percentage points above; the measured number falls inside the stated range.
By their numbers in this assay, from the lowest: compounds 4, 3, 1 and 2 (each within the scatter of the next, the first and the last beyond it).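

For the compounds shown here, at this position, on a nitrogen on an aromatic ring in a ring, 4-methoxy-2-methylphenyl gives the only step beyond the scatter in this assay: a number 11.7 percentage points lower from compound 2 to compound 4 (beyond the scatter). The other two steps, a number 7.8 percentage points lower from compound 3 to compound 4 (within the scatter) and a number 9.1 percentage points lower from compound 1 to compound 4 (within the scatter), stay within it, so this change separates compound 4 from compound 2 alone. Nothing available explains the step. As far as these compounds go, whether an amine, a carboxylic acid or a longer chain in place of the methoxy would raise the inhibition remains open.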